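Flipping one stereocentre of compound 3

A few compounds are considered here, and "the series" means these few. Any claim that something is new, unique, unknown or untested is made for them only; others in the source may bear on it.

Compound 1 `CN1CCN(c2ccc(Nc3ncc4nc(Nc5ccccc5)n([C@H]5CCN(C(=O)OC(C)(C)C)C5)c4n3)cc2)CC1`: "not determined" (no result reported)
Compound 2 `CN1CCN(c2ccc(Nc3ncc4nc(Nc5ccccc5)n([C@@H]5CCNC5)c4n3)cc2)CC1`: "not determined" (no result reported)
Compound 3 `CN1CCN(c2ccc(Nc3ncc4nc(Nc5ccccc5)n([C@@H]5CCN(S(=O)(=O)C6CC6)C5)c4n3)cc2)CC1`: > 10000 nM

The only readout to go on comes from a functional assay on A-431 cells (Homo sapiens) for antiproliferative activity, read by MTT assay, with a stated time of 72 h; on this read-out lower numbers stand for stronger inhibition and higher numbers for weaker inhibition. There, compound 3 gives > 10000 nM, which is a limit and not a number. Within the data shown here, neither compound 1 nor compound 2 has a result, so no measured step is available as a guide.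

Compound 4 `CN1CCN(c2ccc(Nc3ncc4nc(Nc5ccccc5)n([C@H]5CCN(S(=O)(=O)C6CC6)C5)c4n3)cc2)CC1` is still unmeasured: the two compounds have the same atoms and bonds and differ only in configuration as drawn: 1 of 1 stereo elements differ; a stereocentre at a saturated ring carbon is drawn R in compound 3 and S in compound 4. A stereocentre at a saturated ring carbon is drawn R in compound 3 and S in compound 4.

No step beyond the scatter is expected, so compound 4 should stay weak. The expected step is a number no higher from compound 3 to compound 4 (the limit leaves the size open). For compound 4 the estimated value is 10000 nM, with an expected range of 2500 nM to 30000 nM.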

Compound 4, half-maximal inhibitory concentration: 1670 nM
Compound 4: the middle estimate sits 6.0-fold (0.78 log units) above what was measured; the measured number lies below the stated range.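

In this assay, among these compounds, the drawn configuration at this saturated ring carbon matters on its own, which the earlier compounds could not show: the switch from R to S gives an at least 5.9-fold lower number from compound 3 to compound 4 (0.77 log units; beyond the scatter). Compound 3 carries only a limit, so this size is a minimum and the true gap stays unknown, because one end of the step rests on: the limit of > 10000 nM in this assay, at which 1 of the 4 values shown sits. The change can be tied to configuration alone, because nothing else separates the pair: the fact that compounds 3 and 4 differ only in the configuration as drawn

As far as these compounds go, whether the S form keeps this edge with a methylsulfonyl or an acetyl group in place of the cyclopropylsulfonyl group stays open.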